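Urea nitrogen substituent: pentyl chain to cyclopentyl ring

A few compounds are considered here, and "the series" means these few. Any claim that something is new, unique, unknown or untested is made for them only; others in the source may bear on it.

Among the measured compounds shown here, compound 3 `CCCCCNC(=O)Nc1ccc(S(=O)(=O)Oc2ccccc2C(C)C)cc1` shows the lowest of the three numbers so far in a functional assay on MCF7 cells (Homo sapiens) for antiproliferative activity, read by sulforhodamine B assay, with a stated time of 48 h (a higher number here means a weaker inhibitor, a lower number a stronger inhibitor), at 4000 nM. Compound 1 `CC(C)C(=O)Nc1ccc(S(=O)(=O)Oc2ccccc2C(C)C)cc1` gives 8600 nM and compound 2 `CC(C)c1ccccc1OS(=O)(=O)c1ccc(NC(=O)C(C)(C)C)cc1` gives 6500 nM; the measured steps are a 2.2-fold lower number from compound 1 to compound 3 (0.33 log units; beyond the scatter) and a 1.6-fold lower number from compound 2 to compound 3 (0.21 log units; within the scatter), while a 1.3-fold lower number from compound 1 to compound 2 (0.12 log units; within the scatter). Compound 4 `CC(C)c1ccccc1OS(=O)(=O)c1ccc(NC(=O)NC2CCCC2)cc1` differs from compound 3 by cyclopentyl in place of pentyl on an amide-type nitrogen. For the measured compounds named here, both measured steps onto compound 3 concern the substituent on the carbonyl carbon, not a chain-to-ring exchange on the amide-type nitrogen, so no measured step bears directly on this change; the expectation is therefore no step beyond the scatter, no change at the digits printed from compound 3 to compound 4 (within the scatter). Compound 4 is estimated at 4000 nM in this assay, with a range of 1800 nM to 9000 nM.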

Compound 4, half-maximal inhibitory concentration: 6200 nM
Estimate against measurement, compound 4: 1.6-fold (0.19 log units) below; the range from low to high includes it.
By their numbers in this assay, from the lowest: compounds 3, 4, 2 and 1 (each within the scatter of the next, the first and the last beyond it).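

In this assay cyclopentyl in place of pentyl on the amide-type nitrogen gives a 1.6-fold higher number from compound 3 to compound 4 (0.19 log units; within the scatter) and so leaves ring and open chain unseparated at this position. Cyclopentylamino on the carbonyl carbon gives a 1.0-fold lower number from compound 2 to compound 4 (0.02 log units; within the scatter) against tert-butyl and a 1.4-fold lower number from compound 1 to compound 4 (0.14 log units; within the scatter) against isopropyl, whereas against isopropyl pentylamino gives a 2.2-fold lower number from compound 1 to compound 3 (0.33 log units; beyond the scatter) and alone lies beyond the scatter. Nothing at hand explains these steps.

Open: whether a longer chain, a cyclohexyl ring or a chain bearing an amine on this nitrogen would give a step beyond the scatter from compound 3.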